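Ethyl in place of hydrogen on compound 3

This account rests on a few compounds, and the source may have more. Where it says the series, first, only, none or still open, it means among the compounds named here.

Measured so far in a functional assay on HeLa cells (Homo sapiens) for antiproliferative activity, read by MTT assay, with a stated time of 72 h; a lower number here means a stronger inhibitor, a higher number a weaker inhibitor:
- compound 1 `CC(=O)NNC(=O)c1csc2ncc(-c3ccc(C)cc3)n12` gives 74200 nM
- compound 2 `CCCC(=O)NNC(=O)c1csc2ncc(-c3ccc(C)cc3)n12` gives 45600 nM
- compound 3 `COc1ccc(-c2cnc3scc(C(=O)NNC(C)=O)n23)cc1` gives 17900 nM

Compound 3 has the lowest number of the three in this assay, and its gaps to both other compounds lie beyond the scatter. Its nearest neighbour is compound 2 at 45600 nM.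

The next compound is compound 4 `CCCC(=O)NNC(=O)c1csc2ncc(-c3ccc(OC)cc3)n12`, which keeps the methoxy group of compound 3. The change is ethyl in place of hydrogen on a saturated chain carbon bound to a carbonyl carbon.

The same change has been measured once, on the methyl-bearing compounds: a 1.6-fold lower number from compound 1 to compound 2 (0.21 log units; within the scatter). That step is small and within the scatter. The other measured step, a 4.1-fold lower number from compound 1 to compound 3 (0.62 log units; beyond the scatter), is the methoxy in place of methyl change. It is already contained in the value of compound 3 and says nothing directly about the chain. Whether the ethyl step carries over to the methoxy compounds has not been tested.

A small lowering in this assay is therefore expected, probably not beyond the scatter. The expected change is a 1.5-fold lower number from compound 3 to compound 4 (0.17 log units; within the scatter). For compound 4 the estimated value is 12000 nM, with an expected range of 6000 nM to 24000 nM.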

Compound 4, half-maximal inhibitory concentration: 43300 nM
Estimate against measurement, compound 4: 3.6-fold (0.56 log units) below, outside the stated range (above it).
By their numbers in this assay, from the lowest: compound 3; then compounds 4, 2 and 1 (each within the scatter of the next).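

In this assay, the change of acetyl to propylcarbonyl on the methoxy compounds gives a 2.4-fold higher number from compound 3 to compound 4 (0.38 log units; beyond the scatter), so the small step seen on the methyl compounds does not carry over, and the two cores differ beyond the scatter: the same change on two cores in this assay, a 1.6-fold lower number (0.21 log units; within the scatter) from compound 1 to compound 2 and a 2.4-fold higher number (0.38 log units; beyond the scatter) from compound 3 to compound 4, 3.9-fold (0.60 log units) apart, beyond the scatter of two such steps

The methoxy in place of methyl change also depends on the chain, giving a 1.1-fold lower number from compound 2 to compound 4 (0.02 log units; within the scatter) on the propylcarbonyl compounds, so the clear lowering seen on the acetyl compounds is absent there: the same change on two cores in this assay, a 4.1-fold lower number (0.62 log units; beyond the scatter) from compound 1 to compound 3 and a 1.1-fold lower number (0.02 log units; within the scatter) from compound 2 to compound 4, 3.9-fold (0.60 log units) apart, beyond the scatter of two such steps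

Across these compounds the two changes do not add up, and the low number of compound 3, 17900 nM, belongs to methoxy combined with acetyl rather than to the methoxy group alone.

The compounds shown do not tell why the two changes depend on each other. Going by these compounds, it also remains open whether the higher number on the methoxy compounds continues with a longer chain such as pentyl, or how that core responds to a chain ending in an amine or a carboxylic acid, and whether a fluorine or chlorine in place of methoxy on the aromatic carbon keeps the acetyl preference.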